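One added (tert-butyl)carbonyl group and HEK-293T toxicity

The source may report more compounds than this note shows. Statements on the series, on what has been measured and on what is new or still open speak of the compounds shown alone.

- compound 1 (`C=C1[C@H](OCC(C)C)[C@@H](OC(C)=O)[C@@H](OC(C)=O)C(C)(C)[C@@H]2O[C@H]2[C@H](C)[C@H](OC(=O)c2ccccc2)[C@@]2(O)C[C@@](C)(OC(C)=O)[C@H](OC(C)=O)[C@@H]2[C@H]1OCC(C)C`), value (48100 nM)
- compound 2 (`C=C1[C@H](O)[C@@H](O)[C@@H](O)C(C)(C)/C=C/[C@H](C)[C@H](OC(=O)c2ccccc2)[C@@]2(O)C[C@@](C)(O)[C@H](OC(C)=O)[C@@H]2[C@H]1OCC(C)C`), value (> 100000 nM), a limit
- compound 3 (`C=C1[C@H](OC(C)=O)[C@@H](OC(C)=O)[C@@H](O)C(C)(C)/C=C/[C@H](C)[C@H](OC(=O)c2ccccc2)[C@@]2(O)C[C@@](C)(O)[C@H](OC(C)=O)[C@@H]2[C@H]1OCC(C)C`), value (> 100000 nM), a limit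

In a toxicity assay on HEK-293T cells (Homo sapiens) for cytotoxicity, read by MTT assay, with a stated time of 48 h (a higher number here means a weaker inhibitor, a lower number a stronger inhibitor), compound 2 reads (> 100000 nM), which is a limit of the assay and not a number. Compound 2 thus gives no exact starting point, and it belongs to a small group (the limit of > 100000 nM in this assay, at which 2 of the 3 values shown sit) in which most of the set sits. Compound 3 reads (> 100000 nM), which is also a limit. Compound 1 is the only one of the three with a number (48100 nM) so far.

Compound 4 (`C=C1[C@H](O)[C@@H](OC(=O)C(C)(C)C)[C@@H](O)C(C)(C)/C=C/[C@H](C)[C@H](OC(=O)c2ccccc2)[C@@]2(O)C[C@@](C)(O)[C@H](OC(C)=O)[C@@H]2[C@H]1OCC(C)C`) has not yet been measured. It differs from compound 2 by having (tert-butyl)carbonyl in place of hydrogen on an oxygen on a saturated carbon. Going by the values given here, no measured step between compounds that differ in one place is available to guide the size of this change. The expected step (an at least 1.1-fold lower number from compound 2 to compound 4 (0.04 log units; that floor lies within the scatter)) is small, either within the scatter of this assay or a modest move towards stronger inhibition. Among the compounds with values here, that expectation leans on compound 1 (48100 nM), the only number in the set. For compound 4 the estimated value is (90000 nM), with an expected range from (40000 nM) to (200000 nM) in this assay and a fair expected chance of a reading at the limit.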

Compound 4, half-maximal inhibitory concentration: 31700 nM
The estimate for compound 4 lay 2.8-fold (0.45 log units) above the measured number; the measured number lies below the stated range.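

In this assay, putting (tert-butyl)carbonyl in place of hydrogen on an oxygen on a saturated carbon gives an at least 3.1-fold lower number from compound 2 to compound 4 (0.49 log units; beyond the scatter), so this hydroxy to ((tert-butyl)carbonyl)oxy change is enough to bring the reading to a number. Going by these compounds alone, it is the only step in the set between compounds that differ in one place, and it shows directly that this oxygen can affect the reading, which compound 1 and compound 3 could not show, as each differs from compound 2 in more than one place. Compound 2 reads > 100000 nM, which is a limit of the assay and not a number, so the step gives only a floor for the size of the change, and that limit is shared within the set: the limit of > 100000 nM in this assay, at which 2 of the 4 values shown sit.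

The compounds shown leave open whether a propanoyl group, a methyl ether or a carbamate on this same oxygen would also bring the reading to a number, or whether the change depends on the (tert-butyl)carbonyl group itself. They also leave open whether (tert-butyl)carbonyl on one of the other hydroxy groups of compound 2 would give a step of similar size.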